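The source may hold more compounds than are shown below. What is called first, only, known or untested is meant among the compounds shown, and "the series" means these compounds.

Compound 2 `COc1ccc(-c2cnc(NC(=O)c3ccno3)n2C)cc1` is where this account starts. In a toxicity assay on THP-1 cells (Homo sapiens) for inhibition (a higher number here means that more compound is tolerated, a lower number that less compound is tolerated), compound 2 gives only a limit, > 100000 nM. Compound 1 `COc1ccc(-c2cnc(NC(=O)c3cccnc3)n2C)cc1` likewise gives only a limit in this assay, > 100000 nM. The step that the two limits leave unreadable from compound 1 to compound 2 is therefore not readable, and compound 2 stands together with compound 1 at the limit of > 100000 nM in this assay, at which 2 of the 3 values shown sit. Compound 3 `COc1ccc(-c2cnc(NC(=O)c3ccc(F)cc3)n2-c2ccccc2)cc1` differs from compound 2 in several places. In this assay compound 3 gives 8800 nM. Compound 4 `COc1ccc(-c2cnc(NC(=O)c3cccc(F)c3)n2C)cc1`, not yet measured, carries 3-fluorophenyl in place of 1,2-oxazol-5-yl on a carbonyl carbon. Among the compounds with values here, no measured step bears on this change, so no size can be read for it from the data. Compound 4 is expected to give 80000 nM, within 20000 nM to 300000 nM, in this assay. The step of an at least 1.2-fold lower number from compound 2 to compound 4 (0.09 log units; that floor lies within the scatter) is what this estimate means, and a value reported only as a limit is expected to remain quite possible.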

Compound 4, half-maximal cytotoxic concentration: > 100000 nM
Compound 4 ended at the assay's limit (the forecaster's own chance of this, stated with the estimate: 50%); middle value at least 1.2-fold (0.09 log units) from the limit.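

Compound 4, like compound 1 and compound 2, gives only a limit, so no new step can be read among them: the limit of > 100000 nM in this assay, at which 3 of the 4 values shown sit. As far as these compounds go, whether these three compounds differ at all in this assay remains open.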